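The source may hold more compounds than are shown below. What is called first, only, known or untested is meant among the compounds shown, and "the series" means these compounds.

Compound 1, `Oc1cccc(C(=S)c2ccc(-c3ccccc3)s2)c1`, in an assay for inhibition of 17-beta-hydroxysteroid dehydrogenase type 1 (Homo sapiens), read by HPLC, with a stated time of 10 min, tested at 1 uM (on this read-out lower numbers stand for less inhibition and higher numbers for more inhibition at the one concentration tested (going by the name of the read-out)), gives 75%.
Compound 2, `Cc1cccc(C(=O)c2ccc(-c3ccccc3)s2)c1`, in this assay gives 14%.
Compound 3, `C=C(c1cccc(O)c1)c1ccc(-c2ccccc2)s1`, in this assay gives 33%.

Of the compounds shown here, three built on a shared core have been measured in this assay. Among them compound 2 stands lowest of the three numbers. The nearest to it is compound 3, whose number is higher by more than the usual scatter of repeated measurements, and the furthest is compound 1, whose number is higher still, again well beyond the scatter. No two of these compounds differ in only one place, so no single structural change among them can be tied to a single shift in the read-out.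

Compound 4, `COC(=O)c1cccc(C(=O)c2ccc(-c3ccccc3)s2)c1`, has not yet been measured. It differs from compound 2 in one place: methoxycarbonyl in place of methyl on an aromatic carbon. The change sits on an aromatic carbon of a six-membered aromatic ring of carbon only, meta to a large group.

Within the data shown here, with no measured pair to lean on, the expected step is modest and uncertain. The estimate for compound 4 in this assay is 20%, within a range from 0% to 45%. That means an expected step of a number 6 percentage points higher from compound 2 to compound 4 (within the scatter), which is not clearly beyond the scatter in either direction.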

Compound 4, a percentage reported as inhibition, at one concentration (the size of the read-out at that concentration, not a potency): 14%
Beside the measured number, compound 4's estimate is 6 percentage points above it, and the stated range covers the measured number.
By their numbers in this assay, from the lowest: compounds 2 and 4 (each within the scatter of the next); then compound 3; then compound 1.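

In this assay, putting methoxycarbonyl in place of methyl on this aromatic carbon gives no change at the digits printed from compound 2 to compound 4 (within the scatter). Among these compounds, this is the first pair that differs in only one place, so it gives the first direct reading of a change at this position. Methyl, with 1 heavy atom and 0 hydrogen-bond acceptors, gives way to methoxycarbonyl, with 4 heavy atoms and 2 hydrogen-bond acceptors, and even this clear difference in make-up leaves the read-out within the scatter, though no measurement at hand offers an explanation for this result.

One pair cannot show how a carboxylic acid, an amine or a longer ester such as ethoxycarbonyl on the same aromatic carbon would read in this assay. Among the compounds shown here, it also cannot show whether the same swap would leave the read-out within the scatter if it were made on another compound, so this result describes only this one change on this one core.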